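Swapping the Amine on an Alkyne Chain

The source may report more compounds than this note shows. Statements on the series, on what has been measured and on what is new or still open speak of the compounds shown alone.

Measured in a functional assay (ileum) with Cavia porcellus as the target; on this read-out lower numbers stand for tighter binding and higher numbers for weaker binding:
- compound 1 (`CC(=O)N(C(C)=O)C(C)C#CCN1CCCC1`): 280 nM
- compound 2 (`CN(C)CC#CC1CCC(=O)N1C`): 496000 nM
- compound 3 (`CC(=O)N1C(=O)CCC1C#CCN1CCCC1`): 1430 nM

Of these three, compound 3 takes the middle place. Its number is higher than that of compound 1 and far lower than that of compound 2, and both gaps lie beyond the scatter.

The next compound to be tested is compound 4 (`CC(=O)N1C(=O)CCC1C#CCN(C)C`), which has dimethylamino in place of pyrrolidin-1-yl on a saturated chain carbon bound to a triple-bonded carbon. Going by the values given here, no two measured compounds differ in one place only, so this change has no direct precedent here. Among the compounds with values here, compound 2, the only measured compound carrying dimethylamino, stands highest at 496000 nM, but it also differs from compound 3 elsewhere. It therefore hints at a direction and gives no reliable size. A moderate rise beyond the scatter is expected in this assay, well short of the number for compound 2. The expected change is a 5.6-fold higher number from compound 3 to compound 4 (0.75 log units; beyond the scatter). For compound 4, the estimated value is 8000 nM, with an expected range of 2000 nM to 30000 nM.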

Compound 4, dissociation constant: 95600 nM
Compound 4: middle estimate off by 12-fold (1.08 log units), on the low side; measured number above the stated range.
By their numbers in this assay, from the lowest: compound 1; then compound 3; then compound 4; then compound 2.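

In this assay, the change from pyrrolidin-1-yl to dimethylamino on a saturated chain carbon bound to a triple-bonded carbon can now be read directly, with the rest of the molecule the same: a 67-fold higher number from compound 3 to compound 4 (1.83 log units; beyond the scatter) is a large step, so the read-out here depends strongly on which of these two amines is present. The second pair holds dimethylamino fixed and places acetyl in place of methyl on an amide-type nitrogen in a ring, and a 5.2-fold lower number from compound 2 to compound 4 (0.72 log units; beyond the scatter) is a modest step that shows this other place also affects the number, though less than the amine change does in the pairs shown. Nothing available here accounts for the size of either step.

Going by these compounds, whether other amines, such as piperidin-1-yl, morpholin-4-yl or diethylamino, would stay close to pyrrolidin-1-yl or move toward dimethylamino remains open. On these data alone, it is also open whether dimethylamino in place of pyrrolidin-1-yl would produce a step of similar size on the core of compound 1, or whether its effect is specific to the core of compound 3.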